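A few compounds are considered here, and "the series" means these few. Any claim that something is new, unique, unknown or untested is made for them only; others in the source may bear on it.

Series notes. For the measured compounds named here, compound 2 `O=c1cc(CN(Cc2ccc(Cl)cc2)c2cnccn2)c2ccc(F)c(F)c2[nH]1` gives 77 nM in an assay on HEK293 cells for inhibition of Nitric oxide synthase, inducible (Homo sapiens), read by fluorescence (on this read-out lower numbers stand for stronger inhibition and higher numbers for weaker inhibition), and stands highest of the two numbers measured so far; its nearest neighbour is compound 1 `O=c1cc(CN(Cc2ccccc2)c2cnccn2)c2ccc(F)c(F)c2[nH]1`, which in this assay gives 13 nM. Going by the values given here, the one measured step, a 5.9-fold higher number from compound 1 to compound 2 (0.77 log units; beyond the scatter), comes from chloro in place of hydrogen on an aromatic carbon. Compound 3 `O=c1cc(CN(Cc2ccccc2F)c2cnccn2)c2ccc(F)c(F)c2[nH]1` is not yet measured; it differs from compound 2 by 2-fluorophenyl in place of 4-chlorophenyl on a saturated chain carbon bound to a nitrogen on an aromatic ring, that is, 4-chlorobenzyl to 2-fluorobenzyl. Among the compounds with values here, the step from compound 1 to compound 2 bears on this change, since the chloro that entered there now leaves again, while the fluoro that enters has no precedent in this set. From the compounds shown here alone, the fluoro remains untested, so a step toward lower numbers is expected, though smaller than a full reversal of that step, and the estimate for compound 3 is 25 nM, expected to fall between 10 nM and 70 nM, an expected 3.1-fold lower number from compound 2 to compound 3 (0.49 log units; beyond the scatter).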

Compound 3, half-maximal inhibitory concentration: 12 nM
Compound 3: middle estimate off by 2.1-fold (0.32 log units), on the high side, within the range that was stated.
By their numbers in this assay, from the lowest: compounds 3 and 1 (each within the scatter of the next); then compound 2.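

In this assay, a 1.1-fold lower number from compound 1 to compound 3 (0.03 log units; within the scatter) shows that a fluoro on this phenyl group leaves the number within the scatter, so the loss seen in a 5.9-fold higher number from compound 1 to compound 2 (0.77 log units; beyond the scatter) does not extend to every halogen on the benzyl group. The change from 4-chlorobenzyl to 2-fluorobenzyl, a 6.4-fold lower number from compound 2 to compound 3 (0.81 log units; beyond the scatter), recovers that loss, but it alters both the halogen and its place on the phenyl group, so the two contributions cannot be separated. Nothing measured here bears on why the numbers differ.

Still open, from the compounds shown here alone, is whether the weaker number of compound 2 belongs to the chloro itself or to where it sits, which 2-chlorophenyl and 4-fluorophenyl would separate. Also open, going by these compounds, is how a methoxy or an amine on this phenyl group would read.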